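The compounds below may be only part of what the source reports. "The series", "measured", "known", "first", "only" and "open" are said of these compounds alone.

Compound 1 `CC(=O)N(C)c1ccc2[nH]c(-c3n[nH]c4ccccc34)cc2n1` and compound 2 `CN(C(=O)CCc1ccccc1)c1ccc2[nH]c(-c3n[nH]c4ccccc34)cc2n1` share one core and differ only in the group carried on the carbonyl carbon of the amide. In a functional assay on KB cells (Homo sapiens) for antiproliferative activity, read by MTT assay, with a stated time of 72 h (on this read-out higher numbers stand for weaker inhibition and lower numbers for stronger inhibition), compound 1 gives 10300 nM, while compound 2 gives 7380 nM. That change brought a 1.4-fold lower number from compound 1 to compound 2 (0.14 log units; within the scatter), so the two measured compounds lie within the scatter of each other and neither can be called the more potent. Compound 3 `CN(C(=O)c1ccc(F)cc1)c1ccc2[nH]c(-c3n[nH]c4ccccc34)cc2n1` carries 4-fluorophenyl in place of phenethyl on a carbonyl carbon. For the measured compounds named here, the only measured step that touches the group on the carbonyl carbon, a 1.4-fold lower number from compound 1 to compound 2 (0.14 log units; within the scatter), stayed within the scatter, and no measured compound speaks to a fluorine or to an aromatic ring placed on the carbonyl carbon. Compound 3 is therefore expected to show a 1.0-fold higher number from compound 2 to compound 3 (0.01 log units; within the scatter). For compound 3 the estimate is 7500 nM, with a range from 3000 nM to 20000 nM.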

Compound 3, half-maximal inhibitory concentration: 7220 nM
For compound 3 the middle estimate is 1.0-fold (0.02 log units) above the measured one; the range from low to high includes it.
By their numbers in this assay, from the lowest: compounds 3, 2 and 1 (each within the scatter of the next).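

Swapping phenethyl for 4-fluorophenyl on the carbonyl carbon brought a 1.0-fold lower number from compound 2 to compound 3 (0.01 log units; within the scatter) in this assay, and swapping methyl for 4-fluorophenyl at the same place brought a 1.4-fold lower number from compound 1 to compound 3 (0.15 log units; within the scatter) as the second step. The position has thus carried methyl, phenethyl and now an aromatic ring bound directly to the carbonyl carbon, and compounds 1, 2 and 3 all lie within the scatter of one another, so none of these groups separates from the others. No supporting evidence bears on this result.

The compounds shown leave open whether an amine, a carboxylic acid or a longer chain on the carbonyl carbon would move the number beyond the scatter. They also do not separate the fluorine from its ring, which a plain phenyl group at this place would address.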